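Notes on the cyclopropyl series: removing the trifluoromethyl group

The compounds below may be only part of what the source reports. "The series", "measured", "known", "first", "only" and "open" are said of these compounds alone.

Measured so far:
compound 1 `Cn1nc(CN2CCCC2)nc1-c1ccc(C2(C(F)(F)F)CC2)cc1` — > 1000 nM
compound 2 `Cn1nc(CN2CCCC2)nc1-c1ccc2c(c1)CCCC2` — > 1000 nM
compound 3 `Cn1nc(CN2CCCC2)nc1-c1ccc(Cl)c(Cl)c1` — > 1000 nM

In an assay on membranes from Jurkat cells for displacement of a labelled ligand from Sigma intracellular receptor 2 (Homo sapiens), read by scintillation counting, with a stated time of 1 h (on this read-out higher numbers stand for weaker inhibition and lower numbers for stronger inhibition), compound 1 gives > 1000 nM, which is a limit of the assay and not a number. Compound 2 in this assay gives > 1000 nM, likewise a limit. Compound 3 in this assay gives > 1000 nM, again a limit. Among the measured compounds shown here, compound 1 therefore stands at the limit of > 1000 nM in this assay, at which 3 of the 3 values shown sit, and no measured compound separates itself from the others; no step between measured compounds can be stated.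

The next compound, compound 4 `Cn1nc(CN2CCCC2)nc1-c1ccc(C2CC2)cc1`, differs from compound 1 by hydrogen in place of trifluoromethyl on a saturated ring carbon. With every measured value at the limit there is no guide to the size of such a change, so the expected step from compound 1 to compound 4 in this assay is a step that the limit leaves unreadable from compound 1 to compound 4, meaning nothing beyond the scatter in either direction. Compound 4 is accordingly expected in this assay near 2500 nM, within 600 nM to 10000 nM, most likely reported again only as a limit.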

Compound 4, inhibition constant: 1000 nM
The estimate for compound 4 lay 2.5-fold (0.40 log units) above the measured number, and the stated range covers the measured number.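

In this assay, the change from 1-(trifluoromethyl)cyclopropyl to cyclopropyl gives a number no higher from compound 1 to compound 4 (the limit leaves the size open). Compound 4, at 1000 nM, is the first compound shown to carry a reported number and not a limit, so trifluoromethyl on this saturated ring carbon is not needed for a measurable value. The size of any gain cannot be read, because the other values in the series offer no number to compare with: the limit of > 1000 nM in this assay, at which 3 of the 4 values shown sit.

The compounds shown leave open what a hydroxyl group, an amine or a carboxylic acid on a saturated ring carbon of this three-membered ring would read. They also leave open whether any replacement for hydrogen there would move the value clearly beyond the scatter.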